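Replacing the 4-methylphenyl group of compound 2

The compounds below may be only part of what the source reports. "The series", "measured", "known", "first", "only" and "open" are said of these compounds alone.

In a functional assay on HUVEC cells (Homo sapiens) for antiproliferative activity, read by MTT assay, with a stated time of 48 h (a higher number here means a weaker inhibitor, a lower number a stronger inhibitor), compound 1 `Brc1cccc(/C=C/c2nnc(-c3ccc4c(c3)OCCO4)o2)c1` gives 13500 nM, and compound 2 `Cc1ccc(/C=C/c2nnc(-c3ccc4c(c3)OCCO4)o2)cc1` gives 45200 nM, the higher number of the two and so the weaker inhibitor. Among the compounds with values here, the one measured step at this place, a 3.3-fold higher number from compound 1 to compound 2 (0.52 log units; beyond the scatter), is modest. Compound 3 `Fc1ccccc1/C=C/c1nnc(-c2ccc3c(c2)OCCO3)o1` changes the same place: 2-fluorophenyl in place of 4-methylphenyl on a double-bonded chain carbon bound to a double-bonded chain carbon. Its halogen-bearing ring resembles that of compound 1 at 13500 nM, so a modest fall is expected, with no measurement of a fluorine compound yet. The estimated change is a 1.8-fold lower number from compound 2 to compound 3 (0.26 log units; within the scatter). For compound 3, the expected value is 25000 nM, within an estimated range of 9000 nM to 70000 nM.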

Compound 3, half-maximal inhibitory concentration: 1160 nM
Compound 3: the middle estimate sits 22-fold (1.33 log units) above what was measured; measured number outside the range, below it.
By their numbers in this assay, from the lowest: compound 3; then compound 1; then compound 2.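

Changing the aryl group at this place can matter far more than the first pair showed: 2-fluorophenyl gives a 39-fold lower number from compound 2 to compound 3 (1.59 log units; beyond the scatter) and a 12-fold lower number from compound 1 to compound 3 (1.07 log units; beyond the scatter). A halogen on the ring is therefore not enough by itself, as compound 1 also carries one yet remains well short of compound 3. No measured evidence here accounts for this gap.

Compound 1 and compound 3 differ in both the halogen and its ring position, so these two changes cannot be separated. As far as these compounds go, whether a phenyl ring bearing chlorine, a methoxy group or an amine would match 2-fluorophenyl also remains open.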